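The source may hold more compounds than are shown below. What is called first, only, known or untested is meant among the compounds shown, and "the series" means these compounds.

Compound 1 `N#CC1=C(N)Oc2c(N)cc3nc4ccccc4nc3c2C12C(=O)N(Cc1cnnn1-c1ccccc1Br)c1ccccc12` carries a 2-bromophenyl on an aromatic nitrogen, and in a functional assay on MCF7 cells (Homo sapiens) for antiproliferative activity, read by MTT assay, with a stated time of 48 h (on this read-out lower numbers stand for stronger inhibition and higher numbers for weaker inhibition), compound 1 gives 30700 nM. Compound 2 `N#CC1=C(N)Oc2c(N)cc3nc4ccccc4nc3c2C12C(=O)N(Cc1cnnn1-c1ccc([N+](=O)[O-])cc1)c1ccccc12` carries a 4-nitrophenyl there instead. In this assay compound 2 reaches only the limit of the assay, > 50000 nM, which is not a number. Compound 3 `N#CC1=C(N)Oc2c(N)cc3nc4ccccc4nc3c2C12C(=O)N(Cc1cnnn1-c1c(F)cccc1F)c1ccccc12` carries a 2,6-difluorophenyl. In this assay compound 3 likewise stops at a limit, > 50000 nM, so compound 3 stands without a number of its own, only a floor. The steps of an at least 1.6-fold higher number from compound 1 to compound 2 (0.21 log units; that floor lies within the scatter) and an at least 1.6-fold higher number from compound 1 to compound 3 (0.21 log units; that floor lies within the scatter) are both read only as floors, and the step that the two limits leave unreadable from compound 2 to compound 3 cannot be sized at all (the limit of > 50000 nM in this assay, at which 2 of the 3 values shown sit). Compound 4 `Cc1ccc(Cl)cc1-n1nncc1CN1C(=O)C2(C(C#N)=C(N)Oc3c(N)cc4nc5ccccc5nc4c32)c2ccccc21` differs from compound 3 in one place: 5-chloro-2-methylphenyl in place of 2,6-difluorophenyl on an aromatic nitrogen. For the measured compounds named here, no measured step exchanges one such aryl group for another with a readable size; the three aryl groups seen so far all give weak inhibition. Compound 4 is therefore expected to remain weak as well. The step of an at least 1.1-fold lower number from compound 3 to compound 4 (0.04 log units; that floor lies within the scatter) is expected to stay within the scatter. For compound 4 the expected value in this assay is 45000 nM, within 15000 nM to 100000 nM.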

Compound 4, half-maximal inhibitory concentration: 43500 nM
Compound 4: the middle estimate sits 1.0-fold (0.01 log units) above what was measured; low and high end bracket the measured number.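

For the compounds shown here, compound 4 gives a real number in this assay, so this position now has a second aryl group with a measured value, and the one fully readable step between such groups is a 1.4-fold higher number from compound 1 to compound 4 (0.15 log units; within the scatter): 5-chloro-2-methylphenyl and 2-bromophenyl cannot be told apart here. The other two steps, an at least 1.1-fold lower number from compound 3 to compound 4 (0.06 log units; that floor lies within the scatter) and an at least 1.1-fold lower number from compound 2 to compound 4 (0.06 log units; that floor lies within the scatter), do not set these groups apart either. Both remain floors because compounds 2 and 3 each carry a limit, not a number: the limit of > 50000 nM in this assay, at which 2 of the 4 values shown sit.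

The compounds shown carry only substituted phenyl groups on this nitrogen, so it stays open what an amine, a carboxylic acid or a longer alkyl chain would do at this place. Also open, going by these compounds, is whether any change to the shared core would give stronger inhibition.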